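Removing One Chloro Group from Compound 1

This account rests on a few compounds, and the source may have more. Where it says the series, first, only, none or still open, it means among the compounds named here.

Of the compounds shown here, two have been measured so far in a functional assay on HepG2 cells (Homo sapiens) for antiproliferative activity, read by MTT assay; on this read-out lower numbers stand for stronger inhibition and higher numbers for weaker inhibition. Compound 1, with the structure `COc1ccc(-c2ccnc(Nc3ccc(Cl)cc3Cl)n2)cc1`, gives 190 nM in this assay. Compound 2, with the structure `COc1cccc(Nc2nccc(-c3ccc(Br)cc3)n2)c1`, gives 148000 nM in this assay, a far higher number, and the gap between the two lies well beyond the usual scatter. Among the measured compounds shown here, of the two numbers known, compound 1 therefore stands at the lower, more strongly inhibiting end.

The next compound to be measured is compound 3, with the structure `COc1ccc(-c2ccnc(Nc3ccc(Cl)cc3)n2)cc1`. It differs from compound 1 in one place only: hydrogen in place of chloro on an aromatic carbon. The aromatic ring that carries the change keeps its other chloro group, and the rest of the shared core is untouched.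

For the measured compounds named here, no measured pair in this set shows what taking away a single chloro group does to the number in this assay, so the size of the step is open. A small weakening seems the more likely outcome, but a step within the scatter cannot be ruled out. The expected step from compound 1 to compound 3 is a 2.6-fold higher number from compound 1 to compound 3 (0.42 log units; beyond the scatter). For compound 3 the estimate is 500 nM, with a likely range from 150 nM to 2500 nM.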

Compound 3, half-maximal inhibitory concentration: 4500 nM
Beside the measured number, compound 3's estimate is 9.0-fold (0.95 log units) below it; measured number outside the range, above it.
By their numbers in this assay, from the lowest: compound 1; then compound 3; then compound 2.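

In this assay, replacing the chloro group that sits ortho to a large group and meta to the other chloro group with hydrogen gives a 24-fold higher number from compound 1 to compound 3 (1.37 log units; beyond the scatter), a large step for the loss of a single heavy atom. Among the compounds shown here, this is the first measured pair in the set that isolates one change, and it shows that this position is sensitive: the second chloro group and the shared core stay in place, yet they do not keep the number low on their own. The data shown offer no measured explanation for why this one exchange moves the number so far.

The compounds shown leave open whether chloro itself matters at this position, or whether another group there, such as fluoro, methyl or an amine, would keep the number close to that of compound 1. They also leave open what removing the remaining chloro group would do, and compound 2 cannot help here, since it differs from compound 1 in more than one place.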